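Drawing One Ring Carbon with a Single Configuration

The compounds below may be only part of what the source reports. "The series", "measured", "known", "first", "only" and "open" are said of these compounds alone.

Compound 1 `COc1ccc(/C=C\c2cc(OC)c(OC)c(OC)c2)cc1OCc1ccc(CN2CCCCC2C(=O)O)cc1` is measured in a functional assay on MC-38 cells (Mus musculus) for antiproliferative activity, read by CCK-8 assay, with a stated time of 48 h (a higher number here means a weaker inhibitor, a lower number a stronger inhibitor), where compound 1 gives 5400 nM. Among the three numbers shown it stands second highest: compound 2 `COc1ccc(/C=C\c2cc(OC)c(OC)c(OC)c2)cc1OCc1ccc(CN2CC[C@H](O)C2)cc1` gives 7200 nM, and the step of a 1.3-fold higher number from compound 1 to compound 2 (0.12 log units; within the scatter) stays within the scatter, while compound 3 `COc1ccc(/C=C\c2cc(OC)c(OC)c(OC)c2)cc1OCc1ccc(CNCCN(C)C)cc1` gives 1400 nM, and the step of a 3.9-fold lower number from compound 1 to compound 3 (0.59 log units; beyond the scatter) is a modest move beyond it. Compound 4 `COc1ccc(/C=C\c2cc(OC)c(OC)c(OC)c2)cc1OCc1ccc(CN2CCCC[C@@H]2C(=O)O)cc1` differs from compound 1 only in how one stereo element is drawn: the two compounds have the same atoms and bonds; at least one stereo element is drawn with a configuration in one of them and without one in the other: 1 of 2 stereo elements differ; a stereocentre at a saturated ring carbon is drawn without a configuration in compound 1 and R in compound 4. Among the measured compounds shown here, none of the measured steps is of this kind; each of them replaces the whole group on the saturated chain carbon bound to an aromatic carbon, so none bears directly on it. For compound 4 the expected step of a 1.1-fold lower number from compound 1 to compound 4 (0.03 log units; within the scatter) is therefore none beyond the scatter. Compound 4 is estimated at 5000 nM, within 2200 nM to 11000 nM.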

Compound 4, half-maximal inhibitory concentration: > 10000 nM
Compound 4: only a limit was reported (the forecaster's own chance of this, stated with the estimate: 5%); middle value at least 2.0-fold (0.30 log units) away from the limit.
By their numbers in this assay, from the lowest: compound 3; then compounds 1 and 2 (each within the scatter of the next). At a limit, above all of these: compound 4.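

Among the compounds shown here, for the first time the change sits at one ring carbon alone, and compound 4 gives only a limit in this assay rather than a number: the limit of > 10000 nM in this assay, at which 1 of the 4 values shown sits. Drawing that carbon as R gives an at least 1.8-fold higher number from compound 1 to compound 4 (0.26 log units; that floor lies within the scatter), so no real effect of this change is shown, and an at least 1.3-fold higher number from compound 2 to compound 4 (0.14 log units; that floor lies within the scatter) is equally unsettled. Only the comparison with the (2-(dimethylamino)ethyl)amino group clears the scatter, with an at least 7.1-fold higher number from compound 3 to compound 4 (0.85 log units; beyond the scatter), while compounds 1 and 4 differ only as follows: the fact that one of compounds 1 and 4 is drawn with a defined configuration and the other without, at the place where they differ.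

As far as these compounds go, the S form at that ring carbon remains open, as does a methyl ester in place of the carboxylic acid.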